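The source may report more compounds than this note shows. Statements on the series, on what has been measured and on what is new or still open speak of the compounds shown alone.

Measured compounds:
Compound 1, `COC[C@H]1CN(c2ccc(-n3cc(-c4ccccn4)cn3)c(F)c2)C(=O)O1`, gives 36200 nM in a physicochemical assay for solubility, read by HPLC, with a stated time of 24 h; a lower number here means a less soluble compound, a higher number a more soluble compound.
Compound 2, `CCNC(=O)NC[C@H]1CN(c2ccc(-n3cc(-c4ccccn4)cn3)c(F)c2)C(=O)O1`, gives 222000 nM in this assay.

Going by the values given here, compound 2 stands at the highest of the two numbers in this assay; its only neighbour is compound 1, and the single measured step runs a 6.1-fold higher number from compound 1 to compound 2 (0.79 log units; beyond the scatter), which is beyond the scatter.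

Compound 3, `CNC(=O)[C@H]1CN(c2ccc(-n3cc(-c4ccccn4)cn3)c(F)c2)C(=O)O1`, differs from compound 2 in one place: methylcarbamoyl in place of ((ethylcarbamoyl)amino)methyl on a saturated ring carbon. Among the compounds with values here, the only measured step that bears on this change is the one in which the departing group arrived, a 6.1-fold higher number from compound 1 to compound 2 (0.79 log units; beyond the scatter). It bears on it only indirectly, since the group entering compound 3 is neither the methoxy of compound 1 nor the urea of compound 2, and both of the groups counted above carry a hydrogen-bond donor. Because the larger urea group of compound 2 gave 222000 nM while compound 1 gave 36200 nM, compound 3 is expected to fall between these two, with a step of a 2.8-fold lower number from compound 2 to compound 3 (0.44 log units; beyond the scatter). Compound 3 is therefore estimated at 80000 nM in this assay, within a range from 25000 nM to 250000 nM.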

Compound 3, solubility: 26200 nM
Estimate against measurement, compound 3: 3.1-fold (0.48 log units) above; the measured number falls inside the stated range.
By their numbers in this assay, from the lowest: compounds 3 and 1 (each within the scatter of the next); then compound 2.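

In this assay, the higher number seen with the urea side chain does not carry over to every amide-type group on this saturated ring carbon, next to the ring oxygen: replacing ((ethylcarbamoyl)amino)methyl with methylcarbamoyl gives an 8.5-fold lower number from compound 2 to compound 3 (0.93 log units; beyond the scatter). Set against the methoxymethyl group of compound 1, methylcarbamoyl gives a 1.4-fold lower number from compound 1 to compound 3 (0.14 log units; within the scatter), so these two groups are not told apart at this position, and among the three groups shown only ((ethylcarbamoyl)amino)methyl stands clear of the others. No measurement is available that accounts for either step.

The groups ((ethylcarbamoyl)amino)methyl and methylcarbamoyl differ at once in heavy atoms, with 7 against 4, and in hydrogen-bond donors, with 2 against 1, so the compounds shown cannot say which of these differences, or the urea itself, goes with the larger step. From the compounds shown here alone, it also remains open how this position would read with an amine, a carboxylic acid or a longer chain on the amide nitrogen of methylcarbamoyl.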